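The source may hold more compounds than are shown below. What is called first, only, known or untested is meant among the compounds shown, and "the series" means these compounds.

Of the compounds shown here, three sharing one core have been tested in a functional assay on HeLa cells (Homo sapiens) for cytotoxicity, read by MTT assay, with a stated time of 48 h; a higher number here means a weaker inhibitor, a lower number a stronger inhibitor. Compound 1 `Cc1ccc(S(=O)(=O)/N=C(/CCNC2=CC(=O)c3ccccc3C2=O)Nc2ccc(F)cc2)cc1` gives 5890 nM, compound 2 `Cc1ccc(S(=O)(=O)/N=C(/CCNC2=CC(=O)c3ccccc3C2=O)Nc2cccc(C)c2)cc1` gives 9060 nM, and compound 3 `COc1cc(N/C(CCNC2=CC(=O)c3ccccc3C2=O)=N\S(=O)(=O)c2ccc(C)cc2)cc(OC)c1OC` gives 3390 nM. Of the three numbers, compound 2 has the highest, though its gap to compound 1 is within the scatter, a 1.5-fold higher number from compound 1 to compound 2 (0.19 log units; within the scatter), while a 2.7-fold lower number from compound 2 to compound 3 (0.43 log units; beyond the scatter) is modest. Compound 4 `Cc1ccc(S(=O)(=O)/N=C(/CCNC2=CC(=O)c3ccccc3C2=O)NCc2ccccc2)cc1` differs from compound 2 in one place: benzyl in place of 3-methylphenyl on an amine nitrogen. Among the measured compounds shown here, no measured step swaps an aromatic group for a benzyl; the measured steps, a 1.5-fold higher number from compound 1 to compound 2 (0.19 log units; within the scatter), a 1.7-fold lower number from compound 1 to compound 3 (0.24 log units; within the scatter) and a 2.7-fold lower number from compound 2 to compound 3 (0.43 log units; beyond the scatter), only exchange one aromatic group for another, and all stayed small. For compound 4 the expected change is therefore a 1.3-fold lower number from compound 2 to compound 4 (0.11 log units; within the scatter), nothing beyond the scatter. Compound 4 is estimated at 7000 nM, with a range from 3000 nM to 16000 nM.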

Compound 4, half-maximal inhibitory concentration: 3980 nM
Beside the measured number, compound 4's estimate is 1.8-fold (0.25 log units) above it; measured number inside the range.
By their numbers in this assay, from the lowest: compounds 3, 4, 1 and 2 (each within the scatter of the next, the first and the last beyond it).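

With the same atoms joined differently, benzyl in place of 3-methylphenyl on the amine nitrogen gives a 2.3-fold lower number from compound 2 to compound 4 (0.36 log units; beyond the scatter) in this assay, so this change moves the number beyond the scatter. The other two steps, a 1.2-fold higher number from compound 3 to compound 4 (0.07 log units; within the scatter) and a 1.5-fold lower number from compound 1 to compound 4 (0.17 log units; within the scatter), stay within it, which places benzyl level with the 3,4,5-trimethoxyphenyl and 4-fluorophenyl groups at this position. No supporting data explain this shift. As far as these compounds go, whether a phenethyl group, with its longer chain, or a cyclohexyl group, with no aromatic ring, would hold this level remains open.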